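A few compounds are considered here, and "the series" means these few. Any claim that something is new, unique, unknown or untested is made for them only; others in the source may bear on it.

Compound 1 (`C=C1[C@H](OCC(C)C)C[C@@H](OC(=O)c2cccnc2)C(C)(C)/C=C/[C@@H](C)C(=O)[C@@]2(OC(C)=O)C[C@H](C)[C@H](OC(C)=O)[C@@H]2[C@H]1OC(C)=O`): 18.3%
Compound 2 (`C=C1[C@H](OCC(C)C)C[C@@H](OC(=O)c2cccnc2)C(C)(C)/C=C/[C@@H](C)C(=O)[C@@]2(OC(C)=O)C[C@@](C)(OC(C)=O)[C@H](OC(C)=O)[C@@H]2[C@H]1OC(C)=O`): 6.4%

In a functional assay on HeLa cells (Homo sapiens) for inhibition, read by MTT assay, with a stated time of 72 h, tested at 10 ug/mL (on this read-out higher numbers stand for more inhibition of growth at the one concentration tested and lower numbers for less inhibition of growth), compound 2 stands lowest of the two at 6.4%, and its gap to compound 1 lies beyond the scatter. Compound 3 (`C=C1[C@H](OC(C)=O)C[C@@H](OC(=O)c2cccnc2)C(C)(C)/C=C/[C@@H](C)C(=O)[C@@]2(OC(C)=O)C[C@@](C)(OC(C)=O)[C@H](OC(C)=O)[C@@H]2[C@H]1OC(C)=O`) differs from compound 2 in one place, with acetyl in place of isobutyl on an oxygen on a saturated carbon. Within the data shown here, no measured pair shows this change, so in this assay no step beyond the scatter is expected, with any shift more likely upward, since compound 2 at 6.4% already sits low. The expected step is a number 1.6 percentage points higher from compound 2 to compound 3 (within the scatter). For compound 3 the estimated value is 8%, within an expected range of 0% to 20%.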

Compound 3, percent growth inhibition at one concentration: 13.9%
Beside the measured number, compound 3's estimate is 5.9 percentage points below it, and the stated range covers the measured number.
By their numbers in this assay, from the lowest: compounds 2, 3 and 1 (each within the scatter of the next, the first and the last beyond it).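

Acetyl in place of isobutyl on an oxygen on a saturated carbon gives a number 7.5 percentage points higher from compound 2 to compound 3 (within the scatter) in this assay. Among these compounds, this is the first reading at this position, and it shows that, on the core of compound 2, the change from isobutoxy to acetoxy does not move growth inhibition past the usual scatter. No available evidence bears on this result. Going by these compounds, it remains open whether a free hydroxyl, an amine or a longer chain on this carbon would read differently, and whether the same exchange would behave alike on the core of compound 1.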